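Sulfonyl sulfur: methyl(phenyl)amino for benzylamino

The source may report more compounds than this note shows. Statements on the series, on what has been measured and on what is new or still open speak of the compounds shown alone.

Among the compounds with values here, in a functional assay with Rattus norvegicus as the target (on this read-out lower numbers stand for an effect already at smaller amounts and higher numbers for an effect only at larger amounts of compound), compound 1 (`CC1(C)C=C(n2ccccc2=O)c2cc(S(=O)(=O)N=[N+]=[N-])ccc2O1`) gives 16.2 nM, while compound 2 (`CC1(C)C=C(n2ccccc2=O)c2cc(S(=O)(=O)NCc3ccccc3)ccc2O1`) gives 525 nM, the higher of the two numbers so far. Compound 3 (`CN(c1ccccc1)S(=O)(=O)c1ccc2c(c1)C(n1ccccc1=O)=CC(C)(C)O2`) carries methyl(phenyl)amino in place of benzylamino on a sulfonyl sulfur. Within the data shown here, the only measured step, a 32-fold higher number from compound 1 to compound 2 (1.51 log units; beyond the scatter), is large, but it replaces azido with benzylamino, and no measured step covers the present exchange. From the compounds shown here alone, no step beyond the scatter is therefore expected in this assay, and the direction stays open. The expected step is a 1.2-fold lower number from compound 2 to compound 3 (0.07 log units; within the scatter). For compound 3 the estimated value is 450 nM, with an expected range of 120 nM to 1600 nM.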

Compound 3, half-maximal effective concentration: 1.74 nM
Estimate against measurement, compound 3: 260-fold (2.41 log units) above, and the stated range ends above it.
By their numbers in this assay, from the lowest: compound 3; then compound 1; then compound 2.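

On the sulfonyl sulfur, in this assay, rearranging the same atoms from benzylamino to methyl(phenyl)amino moves the number sharply (a 300-fold lower number from compound 2 to compound 3 (2.48 log units; beyond the scatter)), so this position responds strongly to how those atoms are joined. Azido no longer gives the lowest number in the series (a 9.3-fold lower number from compound 1 to compound 3 (0.97 log units; beyond the scatter)). Nothing at hand accounts for either step.

Still open, from the compounds shown here alone, is whether the nitrogen methyl or the phenyl joined directly to nitrogen drives the change; phenylamino and methyl(benzyl)amino would separate the two. Dimethylamino and morpholine would show whether an aromatic ring is needed here at all.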